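Swapping Nitro for Sulfamoyl on a Shared Core

The source may hold more compounds than are shown below. What is called first, only, known or untested is meant among the compounds shown, and "the series" means these compounds.

Compound 1 `O=c1c2c(Nc3ccccc3)nn(-c3ccc([N+](=O)[O-])cc3)c2nc(Nc2ccccc2)n1-c1ccccc1` was tested in a functional assay on the whole organism (strain Wistar albino) for inhibition, with Rattus norvegicus as the target, read by paw edema, with a stated time of 2 h, at a dose of 25 mg/kg by the oral route (a lower number here means less inhibition, a higher number more inhibition at the dose given (going by the name of the read-out)), where compound 1 gives 40.8%. Compound 2 `NS(=O)(=O)c1ccc(-n2nc(Nc3ccccc3)c3c(=O)n(-c4ccccc4)c(Nc4ccccc4)nc32)cc1` differs from it by sulfamoyl in place of nitro on an aromatic carbon, and in this assay compound 2 gives 54.8%, so the swap gives a number 14 percentage points higher from compound 1 to compound 2 (beyond the scatter). Compound 3 `Cc1ccc(Nc2nn(-c3ccc([N+](=O)[O-])cc3)c3nc(Nc4ccccc4)n(-c4ccccc4)c(=O)c23)cc1` differs from compound 1 by methyl in place of hydrogen on an aromatic carbon, and in this assay compound 3 gives 39.8%, a step of a number 1 percentage points lower from compound 1 to compound 3 (within the scatter). Compound 4 `Cc1ccc(Nc2nn(-c3ccc(S(N)(=O)=O)cc3)c3nc(Nc4ccccc4)n(-c4ccccc4)c(=O)c23)cc1` has not been measured; it differs from compound 3 by sulfamoyl in place of nitro on an aromatic carbon. The place is described in the same words as before, so this is the same change seen from compound 1 to compound 2, occurring twice among these compounds. Because a number 14 percentage points higher from compound 1 to compound 2 (beyond the scatter) was modest, a similar rise is expected here, a number 14.2 percentage points higher from compound 3 to compound 4 (beyond the scatter). Compound 4 is thus expected to give 54%, roughly between 42% and 66%.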

Compound 4, a percentage reported as inhibition, in the whole organism at one dose (the size of the read-out at that dose, not a potency): 63.4%
For compound 4 the middle estimate is 9.4 percentage points below the measured one, within the range that was stated.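

In this assay, sulfamoyl in place of nitro carries over from one core to the other, the new step being a number 23.6 percentage points higher from compound 3 to compound 4 (beyond the scatter) and matching the earlier one: the same change on two cores in this assay, a number 14 percentage points higher (beyond the scatter) from compound 1 to compound 2 and a number 23.6 percentage points higher (beyond the scatter) from compound 3 to compound 4, 9.6 percentage points apart, within the scatter of two such steps.
Adding the methyl gives a number 8.6 percentage points higher from compound 2 to compound 4 (within the scatter) and looks the same with either group in place: the same change on two cores in this assay, a number 1 percentage points lower (within the scatter) from compound 1 to compound 3 and a number 8.6 percentage points higher (within the scatter) from compound 2 to compound 4, 9.6 percentage points apart, within the scatter of two such steps.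
This shows the swap holding across just two cores that differ by one methyl, and it does not show that the swap would hold on a core changed elsewhere, or why it raises the number.

The compounds shown leave open whether a carboxylic acid or an amine in place of sulfamoyl would do as well. They also leave open what a longer chain in place of the methyl would do.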